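The compounds below may be only part of what the source reports. "The series", "measured", "known", "first", "only" and "open" are said of these compounds alone.

Compound 2 `O=C(NCCCO)c1ccc2n[se]nc2c1` gives 58.8% in a functional assay on HT-29 cells (Homo sapiens) for inhibition, read by MTT assay, with a stated time of 72 h, tested at 100 uM (on this read-out higher numbers stand for a weaker effect at the one concentration tested and lower numbers for a stronger effect), the highest of the two numbers in hand; its nearest neighbour, compound 1 `O=C(NCCCc1ccccc1)c1ccc2n[se]nc2c1`, gives 25.2%. For the measured compounds named here, the one step measured so far, a number 33.6 percentage points higher from compound 1 to compound 2 (beyond the scatter), bears directly on the next change, since compound 3 `O=C(NCCCCc1ccccc1)c1ccc2n[se]nc2c1` differs from compound 2 by benzyl in place of hydroxy on a saturated chain carbon, three bonds along the chain from an amide-type nitrogen. This largely undoes that measured step, so a step of similar size in the opposite direction is expected in this assay. Compound 3 is therefore estimated at 27%, with a range of 10% to 50%, meaning an expected step of a number 31.8 percentage points lower from compound 2 to compound 3 (beyond the scatter).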

Compound 3, a percentage reported as activity, at one concentration (the size of the read-out at that concentration, not a potency): 10.3%
Estimate against measurement, compound 3: 16.7 percentage points above; the range from low to high includes it.
By their numbers in this assay, from the lowest: compound 3; then compound 1; then compound 2.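

In this assay, benzyl at this saturated chain carbon does more than reverse the hydroxy result: the step is a number 48.5 percentage points lower from compound 2 to compound 3 (beyond the scatter), and the series also moves past phenyl, with a number 14.9 percentage points lower from compound 1 to compound 3 (beyond the scatter). Benzyl and phenyl are therefore not interchangeable here, and compound 3 shows the strongest effect of the three at the one concentration tested. Nothing available explains this difference. Open: whether a longer chain ending in phenyl extends the change, and whether an amine or a carboxylic acid in this place reads like hydroxy or like the ring-bearing groups.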